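Swapping the amine group on compound 2

The compounds below may be only part of what the source reports. "The series", "measured", "known", "first", "only" and "open" are said of these compounds alone.

Compound 1 `CC(C)NC(=O)[C@H]1CC[C@@H](n2/c(=N/C(=O)c3ccc(C#N)c(F)c3)[nH]c3ccc(CN4CCC(C(C)(C)O)CC4)cc32)CC1`: 132 mL.min-1.g-1
Compound 2 `CC(C)NC(=O)[C@H]1CC[C@@H](n2/c(=N/C(=O)c3ccc(F)cc3)[nH]c3ccc(CN4CCC[C@H]4C(C)(C)O)cc32)CC1`: 569 mL.min-1.g-1

In an in vitro ADME assay on microsomes from liver (Homo sapiens) for metabolic stability (on this read-out lower numbers stand for slow clearance and higher numbers for fast clearance), compound 2 stands highest of the two measured compounds at 569 mL.min-1.g-1, while compound 1 gives 132 mL.min-1.g-1, a gap beyond the usual scatter. Compound 3 `CC(C)NC(=O)[C@H]1CC[C@@H](n2/c(=N/C(=O)c3ccc(F)cc3)[nH]c3ccc(CNCC(C)(C)O)cc32)CC1` keeps the rest of compound 2 and changes one group: (2-hydroxy-2-methylpropyl)amino in place of 2-(1-hydroxy-1-methylethyl)pyrrolidin-1-yl on a saturated chain carbon bound to an aromatic carbon. Among the measured compounds shown here, the two measured compounds differ in more than one place, so no measured step covers this change. The expectation therefore rests on compound 2 starting from the higher value, 569 mL.min-1.g-1, and on the entering group being smaller and having no ring. A fall modestly beyond the scatter is expected, an estimated 2.4-fold lower number from compound 2 to compound 3 (0.37 log units; beyond the scatter). The expected value for compound 3 is 240 mL.min-1.g-1, with an estimated range from 90 mL.min-1.g-1 to 550 mL.min-1.g-1.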

Compound 3, intrinsic clearance in microsomes: 233 mL.min-1.g-1
For compound 3 the middle estimate is 1.0-fold (0.01 log units) above the measured one, within the range that was stated.
By their numbers in this assay, from the lowest: compounds 1 and 3 (each within the scatter of the next); then compound 2.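

In this assay, replacing 2-(1-hydroxy-1-methylethyl)pyrrolidin-1-yl with (2-hydroxy-2-methylpropyl)amino gives a 2.4-fold lower number from compound 2 to compound 3 (0.39 log units; beyond the scatter). Among the compounds shown here, this is the first single-place comparison, and it shows that the group on this saturated chain carbon bound to an aromatic carbon can shift the clearance read-out while the rest of the molecule stays the same. The swap changes the size of the group, removes its ring and its defined stereocentre, and adds a hydrogen-bond donor all at once, and nothing measured here explains the fall.

A methylated tertiary amine version of the open chain, or a plain pyrrolidin-1-yl group without the hydroxy-bearing side group, could help separate these changes. As far as these compounds go, whether the same swap gives a similar step alongside the nitrile-bearing benzoyl group of compound 1 also remains open.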